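Series notes: amine substitution on the shared core

A few compounds are considered here, and "the series" means these few. Any claim that something is new, unique, unknown or untested is made for them only; others in the source may bear on it.

Measured compounds in an assay on isolated protein for displacement of a labelled ligand from 5-hydroxytryptamine receptor 6 (Homo sapiens); on this read-out lower numbers stand for stronger inhibition and higher numbers for weaker inhibition:
Compound 1 `NC[C@@H]1CCCc2cc(S(=O)(=O)c3cccc(F)c3)ccc21` gives 0.0794 nM.
Compound 2 `NC(=O)CNC[C@@H]1CCCc2cc(S(=O)(=O)c3cccc(F)c3)ccc21` gives 0.1 nM.
Compound 3 `O=S(=O)(c1cccc(F)c1)c1ccc2c(c1)CCC[C@H]2CNCCO` gives 0.126 nM.

Compound 3 is separated from compound 2 by a 1.3-fold higher number from compound 2 to compound 3 (0.10 log units; within the scatter) and from compound 1 by a 1.6-fold higher number from compound 1 to compound 3 (0.20 log units; within the scatter); nothing here distinguishes the three in this assay.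

Compound 4 `NCC(=O)NC[C@@H]1CCCc2cc(S(=O)(=O)c3cccc(F)c3)ccc21` differs from compound 3 by (aminomethyl)carbonyl in place of 2-hydroxyethyl on an amine nitrogen. The steps bearing on this change are the attachments to the same amine nitrogen: a 1.3-fold higher number from compound 1 to compound 2 (0.10 log units; within the scatter) and a 1.6-fold higher number from compound 1 to compound 3 (0.20 log units; within the scatter), plus the exchange a 1.3-fold higher number from compound 2 to compound 3 (0.10 log units; within the scatter). Every substitution at this nitrogen so far has left the number within the scatter, so the expected outcome for compound 4 is no step beyond the scatter, a 1.0-fold higher number from compound 3 to compound 4 (0.01 log units; within the scatter). Compound 4 is therefore estimated at 0.13 nM, with a range from 0.05 nM to 0.4 nM.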

Compound 4, inhibition constant: 0.316 nM
The estimate for compound 4 lay 2.4-fold (0.39 log units) below the measured number; low and high end bracket the measured number.
By their numbers in this assay, from the lowest: compounds 1, 2 and 3 (each within the scatter of the next); then compound 4.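

For the compounds shown here, compound 4 is the first attachment on this amine nitrogen to move the number beyond the scatter in this assay: a 2.5-fold higher number from compound 3 to compound 4 (0.40 log units; beyond the scatter), a 3.2-fold higher number from compound 2 to compound 4 (0.50 log units; beyond the scatter) and a 4.0-fold higher number from compound 1 to compound 4 (0.60 log units; beyond the scatter). The nitrogen therefore does not treat all attachments alike, since (aminomethyl)carbonyl gives a modest rise while hydrogen, carbamoylmethyl and 2-hydroxyethyl stay within the scatter of one another. No measurement available here accounts for this step.

From the compounds shown here alone, it remains open whether the step goes with the carbonyl on the nitrogen or with the amine in the entering group. An acetyl group on this nitrogen, or a 2-aminoethyl group, would help separate the two.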